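A few compounds are considered here, and "the series" means these few. Any claim that something is new, unique, unknown or untested is made for them only; others in the source may bear on it.

Working notes on the series. Among the measured compounds shown here, compound 2 `Oc1ccc(CNc2cc(Br)cc3[nH]ncc23)cc1Cl` gives 60% in an assay for inhibition of Indoleamine 2,3-dioxygenase 1 (Homo sapiens), with a stated time of 1 h, tested at 10 uM (on this read-out higher numbers stand for more inhibition at the one concentration tested (going by the name of the read-out) and lower numbers for less inhibition), the higher of the two numbers measured so far; compound 1 `Nc1cc(CNc2cc(Br)cc3[nH]ncc23)ccc1O` gives 32% in this assay. For the measured compounds named here, the one measured step, a number 28 percentage points higher from compound 1 to compound 2 (beyond the scatter), shows that the group at this place matters. Compound 3 `Cc1cc(CNc2cc(Br)cc3[nH]ncc23)ccc1O` has not yet been measured in this assay. It differs from compound 2 by methyl in place of chloro on an aromatic carbon. Going by the values given here, no measured step involves methyl at this place, so only the size of the amino-to-chloro step can be taken as a guide to how much this place can move the number. The expectation for compound 3 is therefore a step of a number 10 percentage points lower from compound 2 to compound 3 (within the scatter), most likely within the scatter or a modest fall from compound 2. Compound 3 is estimated to give 50% in this assay, with a range from 30% to 70%.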

Compound 3, a percentage reported as inhibition, at one concentration (the size of the read-out at that concentration, not a potency): 28%
Compound 3: middle estimate off by 22 percentage points, on the high side; the measured number lies below the stated range.
By their numbers in this assay, from the lowest: compounds 3 and 1 (each within the scatter of the next); then compound 2.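

In this assay the gain seen with chloro does not carry over to methyl: there is a number 32 percentage points lower from compound 2 to compound 3 (beyond the scatter) and at the same time a number 4 percentage points lower from compound 1 to compound 3 (within the scatter) so methyl and amino cannot be told apart at this place. Among the three groups compared on this aromatic carbon, ortho to a hydroxy group, chloro alone stands out, and exchanging it for methyl, one heavy atom for one heavy atom with no hydrogen-bond donor or acceptor on either, is enough for a large step. Nothing available explains the gap between chloro and methyl.

As far as these compounds go, whether the higher number belongs to chloro alone or is shared by fluoro, bromo or trifluoromethyl remains open. Also open, from the compounds shown here alone, is how a methoxy group or a nitrile would behave at this place.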